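A few compounds are considered here, and "the series" means these few. Any claim that something is new, unique, unknown or untested is made for them only; others in the source may bear on it.

Measured so far:
- compound 1, `CCC(C)C(NC(=O)n1nnc2ccccc21)C(=O)NC1CCCCC1`: in a functional assay on HEL cells (Homo sapiens) for cytotoxicity (on this read-out higher numbers stand for lower toxicity in this test and lower numbers for higher toxicity in this test), compound 1 gives 80 ug/mL
- compound 2, `CC(C)C(NC(=O)n1nnc2ccccc21)C(=O)NC1CCCC1`: in this assay compound 2 reaches only a limit, > 200 ug/mL

The step followed here leads from compound 2 to compound 3, `CC(C)C(NC(=O)n1nnc2ccccc21)C(=O)NC1CCCCC1`, which has not yet been measured. Compound 2 stands at the limit of > 200 ug/mL in this assay, at which 1 of the 2 values shown sits, so for compound 2 there is a limit rather than a number. The change made is this: cyclohexyl in place of cyclopentyl on an amide-type nitrogen.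

Among the measured compounds shown here, no step between two measured compounds is available to size this change. Compound 1 and compound 2 differ in two places at once, so their two values show only where each of them stands. In this assay the change is expected to be small, toward somewhat higher toxicity or none beyond the scatter, since compound 1 carries cyclohexyl too and gives 80 ug/mL. An expected step of an at least 1.3-fold lower number from compound 2 to compound 3 (0.12 log units; that floor lies within the scatter) follows. Compound 3 is therefore expected at about 150 ug/mL, within a range of 50 ug/mL to 300 ug/mL.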

Compound 3, minimum cytotoxic concentration: >= 80 ug/mL
Compound 3 gave a limit, no number; the forecaster's own chance of this, stated with the estimate: 50%; the middle value lies beyond the limit too.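

In this assay compound 3 gives >= 80 ug/mL, which is a limit and not a number. On these data alone, compound 2 also holds only a limit, so the step between these two compounds cannot be read, and the size of the change from cyclopentyl to cyclohexyl stays unknown. The result does bear on a different change, hydrogen in place of methyl on the saturated chain carbon, which gives a number no lower from compound 1 to compound 3 (the limit leaves the size open), so in this pair that swap shows no sign of making the compound more toxic in this test.

As far as these compounds go, whether cyclohexyl lowers the number at all remains open, and an exact value for compound 3 would be needed to settle it. From the compounds shown here alone, how a phenyl ring or an open hexyl chain on the amide-type nitrogen would read in this assay is also open.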